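Chloro added to the shared core of compound 1

This account rests on a few compounds, and the source may have more. Where it says the series, first, only, none or still open, it means among the compounds named here.

Compound 1 `O=C(Nc1ccc(Sc2nc3ccccc3s2)cc1)c1ccccc1` is the reference point of the set. In an assay on isolated protein for inhibition of thiosulfate sulfurtransferase (Homo sapiens), with a stated time of 60 min, in the absence of a further agent (on this read-out lower numbers stand for stronger inhibition and higher numbers for weaker inhibition), compound 1 gives only a limit of the assay, > 100000 nM. Compound 2 `O=C(Nc1ccc(Sc2nc3ccccc3s2)cc1)c1ccccc1O`, carrying hydroxy in place of hydrogen on an aromatic carbon, likewise returns only a limit, > 100000 nM. Compound 3 `O=C(Nc1ccc(Sc2nc3ccccc3s2)cc1)c1cc(Br)ccc1O`, with 5-bromo-2-hydroxyphenyl in place of phenyl on a carbonyl carbon, also sits at a limit, > 100000 nM. The steps a step that the two limits leave unreadable from compound 1 to compound 2, a step that the two limits leave unreadable from compound 1 to compound 3 and a step that the two limits leave unreadable from compound 2 to compound 3 therefore have no readable size, since all three values rest at the limit of > 100000 nM in this assay, at which 3 of the 3 values shown sit.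

Compound 4 `O=C(Nc1ccc(Sc2nc3ccccc3s2)c(Cl)c1)c1ccccc1` differs from compound 1 by chloro in place of hydrogen on an aromatic carbon. Among the compounds with values here, none of the measured steps touches this position; all of them fall on the carbonyl-bearing ring, and none of them is readable in size. Within the data shown here, there is thus no measured step from which a direction or size for compound 4 can be taken, and compound 1 itself offers only a limit. Compound 4 is expected to remain at the limit as well, estimated at 150000 nM with a range from 50000 nM to 1000000 nM. The expected step that the limit leaves unreadable from compound 1 to compound 4 is accordingly estimated to stay unreadable against the limit.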

Compound 4, half-maximal inhibitory concentration: > 100000 nM
Compound 4 ended at the assay's limit (the forecaster's own chance of this, stated with the estimate: 85%); the middle value lies beyond the limit too.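

Compound 4, like compound 1, rests at a limit, so chloro in place of hydrogen on an aromatic carbon yields no readable step: the limit of > 100000 nM in this assay, at which 4 of the 4 values shown sit.
The compounds shown leave open whether this assay returns a value inside its range for any change on the shared core.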